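Methoxy on the fused ring of compound 3

The source may report more compounds than this note shows. Statements on the series, on what has been measured and on what is new or still open speak of the compounds shown alone.

Three amides share one core. Compound 1 `COc1ccc2nc(NC(=O)c3cn(-c4ccccc4)nc3-c3ccc(F)cc3)sc2c1` gives 33200 nM in a functional assay on HT-29 cells (Homo sapiens) for cytotoxicity, read by MTT assay, with a stated time of 72 h; on this read-out higher numbers stand for weaker inhibition and lower numbers for stronger inhibition. Compound 2 `O=C(Nc1nc2ccccc2s1)c1cn(-c2ccccc2)nc1-c1ccc(Cl)cc1` gives 13700 nM. Compound 3 `COc1ccc(-c2nn(-c3ccccc3)cc2C(=O)Nc2nc3ccccc3s2)cc1` gives 10500 nM, the lowest of the three numbers; its gap to compound 2 lies within the scatter, while compound 1 sits beyond it. Going by the values given here, the only single-point step measured, a 1.3-fold lower number from compound 2 to compound 3 (0.12 log units; within the scatter), concerns the other aryl ring and does not touch the change at hand.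

Compound 4 `COc1ccc(-c2nn(-c3ccccc3)cc2C(=O)Nc2nc3ccc(OC)cc3s2)cc1` differs from compound 3 by methoxy in place of hydrogen on an aromatic carbon. Among the compounds with values here, no measured step isolates this change. Compound 1 also carries a methoxy on the fused two-ring system, yet it differs from compound 2 in a second place as well, so its higher number cannot be assigned to the methoxy alone. Given that, a small rise in number is expected, a 1.9-fold higher number from compound 3 to compound 4 (0.28 log units; within the scatter), with wide uncertainty. Compound 4 is therefore estimated at 20000 nM, within 7000 nM to 60000 nM.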

Compound 4, half-maximal inhibitory concentration: > 50000 nM
Compound 4: only a limit was reported (the forecaster's own chance of this, stated with the estimate: 10%); middle value at least 2.5-fold (0.39 log units) from the limit.
By their numbers in this assay, from the lowest: compounds 3 and 2 (each within the scatter of the next); then compound 1. At a limit, above all of these: compound 4.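

The change from 1,3-benzothiazol-2-yl to 6-methoxy-1,3-benzothiazol-2-yl now has a step of its own in this assay, an at least 4.7-fold higher number from compound 3 to compound 4 (0.67 log units; beyond the scatter), so on the background of compound 3 a methoxy at this position goes with a higher number. Compound 4 gives only a limit, not a number: the limit of > 50000 nM in this assay, at which 1 of the 4 values shown sits. Compound 1 carries the same 6-methoxy-1,3-benzothiazol-2-yl group, and with methoxy in place of fluoro on the other aryl ring, an at least 1.5-fold higher number from compound 1 to compound 4 (0.17 log units; that floor lies within the scatter), the floor does not separate the two.

From the compounds shown here alone, the full size of the methoxy step stays open, and it rests on a single pair. Also open, going by these compounds, is whether a hydroxyl, an amine or a carboxylic acid on this carbon would keep the number close to that of compound 3, 10500 nM.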